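The source may report more compounds than this note shows. Statements on the series, on what has been measured and on what is new or still open speak of the compounds shown alone.

Series notes. Among the compounds with values here, compound 1 `N#CC1=C(N)Oc2c(c3nc4ccccc4nc3c3ccccc23)C12C(=O)N(Cc1cnnn1-c1ccc(Cl)c(Cl)c1)c1ccccc12` and compound 2 `N#CC1=C(N)Oc2c(N)cc3nc4ccccc4nc3c2C12C(=O)N(Cc1cnnn1-c1ccccc1Cl)c1ccccc12` share the core and differ in more than one place, so no single step between them is counted. In a functional assay on HepG2 cells (Homo sapiens) for antiproliferative activity, read by MTT assay, with a stated time of 48 h (on this read-out higher numbers stand for weaker inhibition and lower numbers for stronger inhibition), compound 1 gives only a limit, > 50000 nM, as shown by the limit of > 50000 nM in this assay, at which 1 of the 2 values shown sits. In this assay compound 2 gives 33500 nM. Within the data shown here, compound 2 thus holds the only number in this assay; the other result is a limit, so compound 2 cannot be placed above or below compound 1.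

Compound 3 `N#CC1=C(N)Oc2c(N)cc3nc4ccccc4nc3c2C12C(=O)N(Cc1cnnn1-c1c(F)cccc1F)c1ccccc12` is not yet measured. It differs from compound 2 in one place: 2,6-difluorophenyl in place of 2-chlorophenyl on an aromatic nitrogen.

Among the measured compounds shown here, no step between two measured compounds is available to guide the size of the effect of this change; the two values shown give no direction. The working expectation is a step from compound 2 to compound 3 of a 1.0-fold higher number from compound 2 to compound 3 (0.02 log units; within the scatter), that is, none beyond the scatter. Compound 3 is therefore expected to give about 35000 nM in this assay, with a range from 12000 nM to 100000 nM, and there is a fair chance the result will again be reported only as a limit.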

Compound 3, half-maximal inhibitory concentration: > 50000 nM
Compound 3 ended at the assay's limit; the forecaster's own chance of this, stated with the estimate: 35%; middle value at least 1.4-fold (0.15 log units) from the limit.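

Within the data shown here, the change from 2-chlorophenyl to 2,6-difluorophenyl, on an aromatic nitrogen of the five-membered ring, gives the only step that can be read: an at least 1.4-fold higher number from compound 2 to compound 3 (0.17 log units; that floor lies within the scatter). This step is a floor and not a size, and since the floor lies within the scatter, it shows no gain from 2,6-difluorophenyl in this assay but does not establish a real loss either. Compound 3 gives only a limit, > 50000 nM, so any reading of this position in terms of numbers still rests on compound 2 alone, and the series now sits largely at the top of the measurable range: the limit of > 50000 nM in this assay, at which 2 of the 3 values shown sit.

Going by these compounds, how far compound 3 actually lies from compound 2 stays open, as does whether the outcome goes with the chlorine leaving or with the two fluorines entering. Also open, on these data alone, is whether an unsubstituted phenyl, a 4-methoxyphenyl or a benzyl group in this place would bring a number clearly lower than that of compound 2, which would give this position a measurable range to work with.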